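This account rests on a few compounds, and the source may have more. Where it says the series, first, only, none or still open, it means among the compounds named here.

Measured compounds:
- compound 1, `COc1ccc(C2N=C(SCc3ccccc3)NC(C)=C2C(=O)Nc2ccc(Br)cc2)cc1`: 7.2%
- compound 2, `COc1ccc(C2N=C(SCc3cccc(Cl)c3)NC(C)=C2C(=O)Nc2ccc(Br)cc2)cc1`: 26.8%
- compound 3, `CC1=C(C(=O)Nc2ccc([N+](=O)[O-])cc2)C(c2cccc([N+](=O)[O-])c2)N=C(SCc2ccccc2)N1`: 17.5%

All three numbers come from a functional assay on the whole organism (artery, strain albino) with Rattus norvegicus as the target, with a stated time of 720 min, at a dose of 10 mg/kg by the oral route; on this read-out lower numbers stand for less inhibition and higher numbers for more inhibition at the one dose given (going by the name of the read-out). Compound 1 and compound 2 share a core and differ by chloro in place of hydrogen on an aromatic carbon, a change placed meta to a large group; this step reads a number 19.6 percentage points higher from compound 1 to compound 2 (beyond the scatter). Compound 3 carries a different core; the difference between the two cores is not broken down here. Compound 4, `CC1=C(C(=O)Nc2ccc([N+](=O)[O-])cc2)C(c2cccc([N+](=O)[O-])c2)N=C(SCc2ccccc2Cl)N1`, is not yet measured. It differs from compound 3 by chloro in place of hydrogen on an aromatic carbon, the same kind of change, but here placed ortho to a large group rather than meta to a large group.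

Going by the values given here, with only one earlier step of this kind on a different core and at a different place, a step of a number 9.5 percentage points higher from compound 3 to compound 4 (within the scatter) is expected for compound 4, smaller than the earlier one because a number 19.6 percentage points higher from compound 1 to compound 2 (beyond the scatter) was measured on another core and another position. Compound 4 is thus estimated at 27%, with a range from 10% to 45%.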

Compound 4, a percentage reported as inhibition, in the whole organism at one dose (the size of the read-out at that dose, not a potency): 11.3%
Compound 4: middle estimate off by 15.7 percentage points, on the high side, and the stated range covers the measured number.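

In this assay, chloro in place of hydrogen on an aromatic carbon of the benzyl group gives a number 6.2 percentage points lower from compound 3 to compound 4 (within the scatter), so compound 4 cannot be told apart from compound 3. The change therefore does not carry a fixed gain from one core to the other: the same change on two cores in this assay, a number 19.6 percentage points higher (beyond the scatter) from compound 1 to compound 2 and a number 6.2 percentage points lower (within the scatter) from compound 3 to compound 4, 25.8 percentage points apart, beyond the scatter of two such steps This does not show that the core alone sets the outcome, as the two steps differ in both core and chloro position, and each rests on a single pair.

Open, on these data alone, is whether 2-chlorobenzyl on the core of compound 1 would match the step seen on the core of compound 3. Also open, as far as these compounds go, is how an amine or a carboxylic acid would read on the benzyl ring of either core.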